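This account rests on a few compounds, and the source may have more. Where it says the series, first, only, none or still open, it means among the compounds named here.

Three amide-linked compounds sharing one core have been measured, and a fourth awaits its number. In a functional assay on HeLa cells (Homo sapiens) for antiproliferative activity, read by CCK-8 assay, with a stated time of 72 h, tested at 8 uM (a higher number here means a stronger effect of the compound at the concentration tested, a lower number a weaker effect), compound 1 `Nc1ccccc1NC(=O)c1ccc(CSC(=S)N2CCN(c3cccnc3)CC2)cc1` gives 72.5%. Compound 3 `CC1CCCCN1C(=S)SCc1ccc(C(=O)Nc2ccccc2N)cc1` gives 76.3% in this assay, and compound 2 `Nc1ccccc1NC(=O)c1ccc(CSC(=S)N2CCc3cc(Cl)ccc32)cc1` gives 65.1%; the gap from compound 1 to either of them lies within the scatter of repeated measurements, so the three values cannot be ranked with confidence.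

Compound 4 `CN1CCN(C(=S)SCc2ccc(C(=O)Nc3ccccc3N)cc2)CC1` differs from compound 1 in one place: methyl in place of pyridin-3-yl on an amine nitrogen in a ring. What leaves is pyridin-3-yl, a six-membered aromatic ring with one hetero atom; what enters is methyl, a single carbon without a ring.

For the measured compounds named here, only one measured step speaks to changes in this region, the group attached to the thiocarbonyl carbon: a number 11.2 percentage points higher from compound 2 to compound 3 (beyond the scatter). That step traded one ring-bearing group for another, and its effect was modest. Nothing measured tells how a ring on the piperazine nitrogen compares with a methyl there, so the expectation rests on the narrow spread of the three values. The step from compound 1 to compound 4 is therefore expected to be small, a number 2.5 percentage points lower from compound 1 to compound 4 (within the scatter), not beyond the scatter. Compound 4 is expected to give about 70% in this assay, with a range from 58% to 82%.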

Compound 4, a percentage reported as inhibition, at one concentration (the size of the read-out at that concentration, not a potency): 75.7%
The estimate for compound 4 lay 5.7 percentage points below the measured number, and the stated range covers the measured number.
By their numbers in this assay, from the lowest: compounds 2, 1, 4 and 3 (each within the scatter of the next, the first and the last beyond it).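

On the amine nitrogen in a ring, the pyridin-3-yl with its six heavy atoms gives way to methyl, a single carbon with no ring, with a number 3.2 percentage points higher from compound 1 to compound 4 (within the scatter) in this assay; at this concentration, then, the read-out does not depend on an aromatic ring at this position. The other two steps concern the whole group on the thiocarbonyl carbon: 4-methylpiperazin-1-yl in place of 2-methylpiperidin-1-yl gives a number 0.6 percentage points lower from compound 3 to compound 4 (within the scatter), while the same group in place of 5-chloro-2,3-dihydro-1H-indol-1-yl gives a number 10.6 percentage points higher from compound 2 to compound 4 (beyond the scatter), a modest step that matches the one seen earlier with 2-methylpiperidin-1-yl. Nothing measured here explains why these groups give such similar numbers.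

The compounds shown leave open whether a plain hydrogen, a longer chain such as propyl, or a chain ending in a carboxylic acid on this nitrogen would keep the read-out in the same range. Since each number is the size of the effect at a single concentration, similar values could still hide differences in potency that a full concentration series would reveal.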